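A few compounds are considered here, and "the series" means these few. Any claim that something is new, unique, unknown or untested is made for them only; others in the source may bear on it.

Working notes on the series in an ADME assay on LLC-PK1 cells (Sus scrofa) for permeability, read by LC-MS, with a stated time of 2 h, tested at 5 uM; on this read-out higher numbers stand for higher permeability and lower numbers for lower permeability. Of the compounds shown here, two have numbers so far. Compound 1 `COc1cc2c(cn1)Oc1ccc(NC(=O)c3ccc(Cl)cn3)cc1[C@@]21COC(N)=N1` carries a methoxy on the ring nitrogen-bearing aromatic ring of the shared core; in this assay compound 1 gives 25 nm/s. Compound 2 `NC1=N[C@@]2(CO1)c1cc(NC(=O)c3ccc(Cl)cn3)ccc1Oc1cnc(Cl)cc12` carries a chloro at the same place; in this assay compound 2 gives 28 nm/s. Among the measured compounds shown here, the single measured step, a 1.1-fold higher number from compound 1 to compound 2 (0.05 log units; within the scatter), is within the scatter, so the two compounds cannot be ordered on these numbers. Compound 2 thus stands with the higher of two numbers, but only by a margin that the scatter covers.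

Compound 3 `Cc1cc2c(cn1)Oc1ccc(NC(=O)c3ccc(Cl)cn3)cc1[C@@]21COC(N)=N1` is the next member, not yet measured. Its difference from compound 2 is methyl in place of chloro on an aromatic carbon. For the measured compounds named here, the one measured step at this position, a 1.1-fold higher number from compound 1 to compound 2 (0.05 log units; within the scatter), bears on it directly and was within the scatter; a methoxy and a chloro gave indistinguishable numbers there, and nothing in the data points to a methyl behaving otherwise. The expectation is therefore no step beyond the scatter, a 1.0-fold lower number from compound 2 to compound 3 (0.02 log units; within the scatter). Compound 3 is estimated at 27 nm/s, with a range from 14 nm/s to 55 nm/s.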

Compound 3, apparent permeability: 40 nm/s
Beside the measured number, compound 3's estimate is 1.5-fold (0.17 log units) below it; the range from low to high includes it.
By their numbers in this assay, from the lowest: compounds 1, 2 and 3 (each within the scatter of the next).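

In this assay, the aromatic carbon next to the ring nitrogen now has three measured substituents, with methyl joining methoxy and chloro. Among the compounds shown here, the new comparisons, a 1.4-fold higher number from compound 2 to compound 3 (0.15 log units; within the scatter) and a 1.6-fold higher number from compound 1 to compound 3 (0.20 log units; within the scatter), both stay inside the scatter, as did the single comparison available before, so this position has taken all three groups without a step beyond the scatter and the three compounds cannot be ordered on these numbers. No measurement in hand offers an explanation for the numbers of these compounds.

The compounds shown leave open whether a group of another kind on this carbon, such as an amine, a carboxylic acid or a longer chain, would give a step beyond the scatter. They also leave open whether the same flat picture would hold with a different amide part, as compounds 1, 2 and 3 all share one amide and differ only at this single position.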